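A Methyl on the Chain of Compound 3

The compounds below may be only part of what the source reports. "The series", "measured", "known", "first", "only" and "open" are said of these compounds alone.

In a functional assay on the whole organism for antagonist activity, with Mus musculus as the target (a lower number here means that less compound is needed, a higher number that more compound is needed for the effect), compound 3 (`CCOC(=O)N(C)CC#CCn1cncc1C`) gives 66 mg/kg as its number, level with compound 2 (`CCOC(=O)N(C)CC#CCn1ccnc1`) at 97 mg/kg and well above compound 1 (`COC(=O)N(C)CC#CCn1cncc1C`) at 3 mg/kg in this set. Compound 4 (`CCOC(=O)N(C)C(C)C#CCn1cncc1C`) differs from compound 3 by one change: methyl in place of hydrogen on a saturated chain carbon bound to an amide-type nitrogen and a triple-bonded carbon. Neither measured methyl step sits at that place. On a saturated chain carbon bound to an oxygen, methyl gave a 22-fold higher number from compound 1 to compound 3 (1.34 log units; beyond the scatter) as a large step; on an aromatic carbon, it gave a 1.5-fold lower number from compound 2 to compound 3 (0.17 log units; within the scatter) within the scatter. With one large step and one within the scatter, no step beyond the scatter is firmly expected in this assay in either direction, though the uncertainty is wide. The estimated change is a 1.2-fold higher number from compound 3 to compound 4 (0.08 log units; within the scatter) and remains only an expectation. Compound 4 is expected at 80 mg/kg within a range of 20 mg/kg to 300 mg/kg for now.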

Compound 4, dose for half-maximal effect: 9.7 mg/kg
Compound 4: middle estimate off by 8.2-fold (0.92 log units), on the high side; the measured number lies below the stated range.
By their numbers in this assay, from the lowest: compound 1; then compound 4; then compounds 3 and 2 (each within the scatter of the next).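

In this assay, methyl in place of hydrogen on a saturated chain carbon bound to an amide-type nitrogen and a triple-bonded carbon gives a 6.8-fold lower number from compound 3 to compound 4 (0.83 log units; beyond the scatter). Among these compounds, this is the first step at this place, and it shows that the number can fall beyond the scatter when a methyl is added, which neither earlier methyl step showed. Nothing at hand gives a reason for this step.

On these data alone, it remains open whether an ethyl group or a longer chain on this carbon would lower the number further or raise it again. Also open, as far as these compounds go, is whether the same methyl would give a step of similar size on compound 1.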